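This account rests on a few compounds, and the source may have more. Where it says the series, first, only, none or still open, it means among the compounds named here.

Working notes on the series. Compound 1 `COc1cccc(NC(=O)CSc2nc(Nc3ccccc3)c3ccccc3n2)c1` gives 10000 nM in a functional assay on MGC-803 cells (Homo sapiens) for inhibition, read by MTT assay, with a stated time of 72 h; on this read-out higher numbers stand for weaker inhibition and lower numbers for stronger inhibition. Compound 2 `C=CC(=O)Nc1cccc(NC(=O)CSc2nc(Nc3ccccc3)c3ccccc3n2)c1` gives 7310 nM in this assay, the step being a 1.4-fold lower number from compound 1 to compound 2 (0.14 log units; within the scatter). Compound 3 `C=CC(=O)Nc1cccc(NC(=O)CSc2nc(Nc3ccccc3F)c3ccccc3n2)c1` gives 26100 nM in this assay; this is the highest number among the three measured compounds, and the step of a 3.6-fold higher number from compound 2 to compound 3 (0.55 log units; beyond the scatter) is the only one in the set that moved the number beyond the scatter.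

Compound 4 `C=CC(=O)Nc1cccc(NC(=O)CSc2nc(Nc3ccccc3Cl)c3ccccc3n2)c1` has not yet been measured. It differs from compound 3 by chloro in place of fluoro on an aromatic carbon. Among the measured compounds shown here, no measured step exchanges one halogen for another on that ring; the fluoro-for-hydrogen step is the closest precedent and it was modest, so it gives no direction for a chloro-for-fluoro exchange. The step is therefore expected to be a 1.0-fold lower number from compound 3 to compound 4 (0.02 log units; within the scatter), that is, nothing beyond the scatter. Compound 4 is estimated at 25000 nM in this assay, with a range from 10000 nM to 60000 nM.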

Compound 4, half-maximal inhibitory concentration: 20700 nM
For compound 4 the middle estimate is 1.2-fold (0.08 log units) above the measured one; the measured number falls inside the stated range.
By their numbers in this assay, from the lowest: compounds 2 and 1 (each within the scatter of the next); then compounds 4 and 3 (each within the scatter of the next).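

In this assay, chloro in place of fluoro at this position, on an aromatic carbon ortho to a large group, gives a 1.3-fold lower number from compound 3 to compound 4 (0.10 log units; within the scatter), so the two halogens are not separated here. Set against hydrogen, chloro gives a 2.8-fold higher number from compound 2 to compound 4 (0.45 log units; beyond the scatter), a modest rise beyond the scatter in the same direction as a 3.6-fold higher number from compound 2 to compound 3 (0.55 log units; beyond the scatter), so both halogens shown at this position give a higher number than hydrogen, and neither compound 3 nor compound 4 goes against this. No measurement on hand explains this rise.

Going by these compounds, it remains open whether a non-halogen group here, such as methyl, methoxy or an amine, would also raise the number above that of compound 2. On these data alone, it is also open whether chloro would give a similar rise elsewhere on that ring, or with methoxy in place of (vinylcarbonyl)amino, as in compound 1.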